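This account rests on a few compounds, and the source may have more. Where it says the series, first, only, none or still open, it means among the compounds named here.

Series notes. Compound 1 `O=c1c2ncn(-c3ccccc3)c2nc(N2CCCCC2)n1-c1ccc(Cl)cc1` carries a piperidin-1-yl group on the shared core. In a functional assay on KB cells (Homo sapiens) for cytotoxicity, read by MTT assay, with a stated time of 72 h (a lower number here means a stronger inhibitor, a higher number a weaker inhibitor), compound 1 gives 72800 nM. Among the measured compounds shown here, this is the only number reported so far for the series, so compound 1 stands as the single measured point against which anything new is read. Compound 2 `CNc1nc2c(ncn2-c2ccccc2)c(=O)n1-c1ccccc1` carries methylamino in the same position. In this assay compound 2 reaches only a limit of the assay, > 100000 nM. The line the limit of > 100000 nM in this assay, at which 1 of the 2 values shown sits, marks where the remainder of the data sits. Compound 3 `O=c1c2ncn(-c3ccccc3)c2nc(NCc2ccccc2)n1-c1ccc(Cl)cc1` is not yet measured. Its change from compound 1 is benzylamino in place of piperidin-1-yl on an aromatic carbon, between two ring nitrogen atoms and ortho to the 4-chlorophenyl group. For the measured compounds named here, no measured pair bearing this change exists in the set, so the size of the step in this assay is open; no direction beyond the usual scatter is expected. The estimate for compound 3 in this assay is 60000 nM, with a range from 15000 nM to 150000 nM. The step implied, a 1.2-fold lower number from compound 1 to compound 3 (0.08 log units; within the scatter), is expected to stay within the scatter.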

Compound 3, half-maximal inhibitory concentration: 34300 nM
Estimate against measurement, compound 3: 1.7-fold (0.24 log units) above; the measured number falls inside the stated range.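

Among the compounds shown here, at the position between two ring nitrogen atoms and ortho to the 4-chlorophenyl group, the exchange of piperidin-1-yl for benzylamino gives the first readable step in this assay, with a 2.1-fold lower number from compound 1 to compound 3 (0.33 log units; beyond the scatter). The position therefore responds to the group it carries, though only modestly on this single pair, and the change brings in an aromatic ring of carbon only and a hydrogen-bond donor at once, so this step cannot assign the difference to either. Cytotoxicity in the series stays weak on the numbers shown, and compound 2 gives only a limit of the assay rather than a number: the limit of > 100000 nM in this assay, at which 1 of the 3 values shown sits.

Still open, going by these compounds, is whether the step follows the hydrogen-bond donor or the aromatic ring, a question that cyclohexylamino, which has the donor without the aromatic ring, and methyl(benzyl)amino, which has the aromatic ring without the donor, would separate at this position. Also open, on these data alone, is whether a morpholin-4-yl group or a longer chain such as 2-phenylethylamino would move the number further from that of compound 3.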